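Cyclopentylamino Replaces Cyclopentyl: Expected Liver Microsome Clearance

The source may report more compounds than this note shows. Statements on the series, on what has been measured and on what is new or still open speak of the compounds shown alone.

The account follows the step from compound 2 to compound 4. Among the compounds with values here, compound 2 `COc1cnc(-c2ccccn2)nc1C1CCCC1` gives 749 mL/min/kg in an in vitro ADME assay on microsomes from liver (Homo sapiens) for metabolic stability, read by LC-MS, tested at 0.05 uM (on this read-out lower numbers stand for slow clearance and higher numbers for fast clearance), the highest of the three numbers so far. Its nearest neighbour is compound 1 `COc1cnc(-c2ccccn2)nc1N1CCCC1`, which gives 458 mL/min/kg; the step of a 1.6-fold higher number from compound 1 to compound 2 (0.21 log units; within the scatter) lies within the scatter. Furthest away is compound 3 `COc1cnc(-c2ccccn2)nc1NCc1ccccc1Cl`, which gives 55 mL/min/kg, a number far below that of compound 2 and beyond the scatter.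

Compound 4 `COc1cnc(-c2ccccn2)nc1NC1CCCC1` differs from compound 2 in one place: cyclopentylamino in place of cyclopentyl on an aromatic carbon.

Within the data shown here, only one measured step touches this position, the change from compound 1 to compound 2, and it was small. Among the measured compounds shown here, no measured pair isolates the entry of an amino link on its own. What bears on it indirectly is compound 3, whose substituent also attaches through an amino group and whose value of 55 mL/min/kg sits far below compound 2. On that basis a lower number is expected for compound 4, though with wide uncertainty since the cyclopentyl ring is retained. The expected step is a 3.0-fold lower number from compound 2 to compound 4 (0.48 log units; beyond the scatter). Compound 4 is therefore estimated to give 250 mL/min/kg, with a range from 70 mL/min/kg to 700 mL/min/kg.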

Compound 4, clearance: 210 mL/min/kg
Compound 4: the middle estimate sits 1.2-fold (0.08 log units) above what was measured; low and high end bracket the measured number.
By their numbers in this assay, from the lowest: compound 3; then compound 4; then compounds 1 and 2 (each within the scatter of the next).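

In this assay, within the data shown here, cyclopentylamino in place of cyclopentyl gives a 3.6-fold lower number from compound 2 to compound 4 (0.55 log units; beyond the scatter), the first step at this position that lies beyond the scatter, and it comes with the five-membered carbon ring retained. The earlier step, a 1.6-fold higher number from compound 1 to compound 2 (0.21 log units; within the scatter), had left compound 1 and compound 2 within the scatter of each other, so it gave no sign that a change at this position could move the number measurably. Cyclopentylamino in place of pyrrolidin-1-yl now gives a 2.2-fold lower number from compound 1 to compound 4 (0.34 log units; beyond the scatter), which is also beyond the scatter, so compound 4 stands apart from both of these neighbours, though both steps are modest. Nothing measured among these compounds explains the steps.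

As far as these compounds go, it remains open whether the lower number follows from the amino link alone or depends on the cyclopentyl ring attached to it, and what an open chain such as isopropylamino or a cyclopentyloxy group would give at this position. From the compounds shown here alone, it also remains open whether the same exchange would give a step of similar size with another group in place of the methoxy group or the pyridin-2-yl group.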